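The source may report more compounds than this note shows. Statements on the series, on what has been measured and on what is new or still open speak of the compounds shown alone.

The series shares one core, seen in compound 1 `O=C1C=C(NC2CCCCC2)C(=O)c2c1nc1n2[C@H]2OC[C@@H](O)[C@H]2OC1`, which carries a cyclohexyl group on its amine nitrogen. In a functional assay on ECa-109 cells for inhibition, with ECa-109 cell line (Homo sapiens) as the target, read by sulforhodamine B assay (a lower number here means a stronger inhibitor, a higher number a weaker inhibitor), compound 1 gives only a limit, > 16000 nM, and no number. Compound 2 `COc1ccccc1NC1=CC(=O)c2c(nc3n2[C@H]2OC[C@@H](O)[C@H]2OC3)C1=O` carries a 2-methoxyphenyl group in the same place. In this assay compound 2 also gives only a limit, > 4000 nM, and no number. Of the two values shown, then, compound 2 sits at one limit and compound 1 at the other, so neither compound has a measured number against which the next member can be set. Compound 3 `O=C1C(Nc2cccc(F)c2)=CC(=O)c2c1nc1n2[C@H]2OC[C@@H](O)[C@H]2OC1` differs from compound 2 by 3-fluorophenyl in place of 2-methoxyphenyl on an amine nitrogen. For the measured compounds named here, no step between two measured compounds exists here, so the size of this change cannot be scaled against anything already seen, and the record so far shows no aryl group on the amine nitrogen reaching a number in this assay. The expected step that the limit leaves unreadable from compound 2 to compound 3 is therefore small, with compound 3 expected to stay weak. For compound 3 the estimate in this assay is 10000 nM, within a range from 3000 nM to 40000 nM.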

Compound 3, half-maximal inhibitory concentration: 2370 nM
Beside the measured number, compound 3's estimate is 4.2-fold (0.63 log units) above it, and the stated range ends above it.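

In this assay, compound 3 is the only one of the three compounds shown to give a measured number, 2370 nM, so an aryl group on this amine nitrogen can reach a number in this assay. Placing 3-fluorophenyl on the amine nitrogen in place of 2-methoxyphenyl gives an at least 1.6-fold lower number from compound 2 to compound 3 (0.22 log units; that floor lies within the scatter), which means that the step is not shown to lie beyond the usual scatter of repeated measurements, although its true size may be larger. For compound 2 the value is a limit and not a number, so the step can be read only as a floor: the limit of > 4000 nM in this assay, at which 1 of the 3 values shown sits.

The compounds shown leave open whether the number reached by compound 3 goes with the fluorine it gains, with the methoxy group it loses, or with the different place of the substituent on the phenyl ring, as this one change alters all of these together. An unsubstituted phenyl group on the same amine nitrogen would help to separate them, and a benzyl group there would show whether the aryl ring must sit directly on that nitrogen.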